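The source may report more compounds than this note shows. Statements on the series, on what has been measured and on what is new or still open speak of the compounds shown alone.

Three compounds share one core and differ only in the group carried on an aromatic nitrogen of the five-membered ring. Compound 1 `CC(C)(C)n1c(=O)n(Cc2cc3cc(Cl)ccc3n2CCCS(C)(=O)=O)c2cnccc21` carries a tert-butyl there. In an ADME assay on HeLa cells (Homo sapiens) for cytotoxicity, read by ATP content, with a stated time of 3 days (a lower number here means that less compound is tolerated, a higher number that more compound is tolerated), compound 1 reaches only a limit of the assay, > 50000 nM. Compound 2 `CS(=O)(=O)CCCn1c(Cn2c(=O)n(CC#N)c3ccncc32)cc2cc(Cl)ccc21` carries a cyanomethyl. In this assay compound 2 likewise gives a limit, > 50000 nM. Compound 3 `CC1(n2c(=O)n(Cc3cc4cc(Cl)ccc4n3CCCS(C)(=O)=O)c3cnccc32)CC1` carries a 1-methylcyclopropyl. In this assay compound 3 also stops at a limit, > 50000 nM. Because every value sits at the limit of > 50000 nM in this assay, at which 3 of the 3 values shown sit, the steps a step that the two limits leave unreadable from compound 1 to compound 2, a step that the two limits leave unreadable from compound 1 to compound 3 and a step that the two limits leave unreadable from compound 2 to compound 3 cannot be sized at all: compound 3 stands at the same limit as the two others, and no ordering among the three is readable.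

Compound 4 `CC(C)n1c(=O)n(Cc2cc3cc(Cl)ccc3n2CCCS(C)(=O)=O)c2cnccc21` is not yet measured. The change from compound 3 is isopropyl in place of 1-methylcyclopropyl on an aromatic nitrogen. All three measured steps bear on this position, and each of them was unreadable, with a size that the limits hide. The expectation is therefore that compound 4 also tolerates the highest tested amount, with no step beyond the scatter. The step expected is a number no higher from compound 3 to compound 4 (the limit leaves the size open). Compound 4 is estimated at 50000 nM, within a range from 15000 nM to 50000 nM, most likely reported again as a limit.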

Compound 4, half-maximal cytotoxic concentration: > 50000 nM
Compound 4 ended at the assay's limit; the forecaster's own chance of this, stated with the estimate: 85%; the middle value lies on the limit itself.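

In this assay compound 4 gives > 50000 nM, again a limit and not a number. Going by these compounds alone, no step from compound 1, compound 2 or compound 3 to compound 4 can be read: the limit of > 50000 nM in this assay, at which 4 of the 4 values shown sit. The compounds shown leave open what concentration any of the four would need to reach half-maximal cytotoxicity, and whether the group on the aromatic nitrogen alters it.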